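A few compounds are considered here, and "the series" means these few. Any claim that something is new, unique, unknown or untested is made for them only; others in the source may bear on it.

Working notes on the series. Within the data shown here, the starting point is compound 1 `O=c1[nH]c(=O)n([C@H]2C[C@H](O)[C@@H](CO)O2)cc1/C=C/I`, which in an ADME assay on L1210/0 cells (Mus musculus) for cytotoxicity, with a stated time of 48 h (a lower number here means a stronger inhibitor, a higher number a weaker inhibitor), gives 63900 nM; it is the only compound of the two measured for which a number rather than a limit is recorded. Compound 2 `CC1(C)[C@@H](CO)CC[C@@]1(C)Cn1cnc2c(N)ncnc21`, built on a different core, returns only a limit in this assay, > 200000 nM. Among the measured compounds shown here, what is known of the measured values is the limit of > 200000 nM in this assay, at which 1 of the 2 values shown sits; it shows where one of the two results sits and gives no measured step that could be used as a guide.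

The next compound is compound 3 `COCC#Cc1cn([C@H]2C[C@H](O)[C@@H](CO)O2)c(=O)[nH]c1=O`. It differs from compound 1 by the change (3-methoxyprop-1-yn-1-yl in place of 2-iodoethenyl on an aromatic carbon). For the measured compounds named here, no measured pair of this kind is available, so the size of the step in this assay is open; with only one number on the core of compound 1 and no measured change beside it, the expectation is for a step that stays within or only slightly beyond the usual scatter, in either direction. Compound 3 is expected at about 90000 nM in this assay, with a range of 20000 nM to 300000 nM. The step that this estimate implies, a 1.4-fold higher number from compound 1 to compound 3 (0.15 log units; within the scatter), is expected to be small.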

Compound 3, half-maximal inhibitory concentration: > 200000 nM
Compound 3 gave a limit, no number; the forecaster's own chance of this, stated with the estimate: 30%; at least 2.2-fold (0.34 log units) between middle value and limit.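

Among these compounds, at this aromatic carbon, 3-methoxyprop-1-yn-1-yl in place of 2-iodoethenyl gives an at least 3.1-fold higher number from compound 1 to compound 3 (0.49 log units; beyond the scatter) and so provides the first measured step, showing that the result in this assay responds to the group carried at this position on the shared core. Only the lower bound of this step is fixed, since the result for compound 3 is a limit and not a number. Compound 1 therefore remains the only compound with a number, and the results for the others are limits: the limit of > 200000 nM in this assay, at which 2 of the 3 values shown sit.

The change replaces a double bond with a triple bond, removes iodine and adds a methoxy end all at once, so the compounds shown cannot assign the step to any one of these features. On these data alone, whether a 2-bromoethenyl group, a plain prop-1-yn-1-yl group or a longer chain ending in an amine at this position would stay close to compound 1 or also return a limit remains open.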